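The source may report more compounds than this note shows. Statements on the series, on what has been measured and on what is new or still open speak of the compounds shown alone.

Measured compounds:
compound 1, `O=C(O)CCCSCCN1C(=O)OC[C@@H]1/C=C/[C@@H](O)Cc1ccccc1` — > 10000 nM
compound 2, `O=C(O)CCCSCCN1C(=O)SC[C@@H]1/C=C/[C@@H](O)Cc1ccccc1` — > 10000 nM

In an assay on CHO cells for displacement of a labelled ligand from prostaglandin E2 receptor EP1 subtype (Mus musculus), read by scintillation counting, with a stated time of 20 min (on this read-out higher numbers stand for weaker inhibition and lower numbers for stronger inhibition), compound 1 gives > 10000 nM, which is a limit of the assay and not a number. Compound 2 gives > 10000 nM in this assay, again a limit rather than a measured number. For the measured compounds named here, compound 2 therefore stands exactly where every value so far stands, namely at the limit of > 10000 nM in this assay, at which 2 of the 2 values shown sit. Going by the values given here, no measured pair differs in one place, so no step between measured compounds can be followed, and nothing shows yet whether any change in this part of the structure moves the inhibition constant.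

Compound 3, `COCc1cccc(C[C@H](O)/C=C/[C@H]2CSC(=O)N2CCSCCCC(=O)O)c1`, differs from compound 2 in one place: methoxymethyl in place of hydrogen on an aromatic carbon. With compound 2 sitting only at a limit, the starting point itself is uncertain. The step of an at least 2.0-fold lower number from compound 2 to compound 3 (0.30 log units; that floor lies within the scatter) is expected to lean toward stronger inhibition, though possibly not beyond the scatter. Compound 3 is expected to give about 5000 nM, within a range from 500 nM to 20000 nM.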

Compound 3, inhibition constant: > 10000 nM
Compound 3: a limit, no number (the forecaster's own chance of this, stated with the estimate: 55%); middle value at least 2.0-fold (0.30 log units) away from the limit.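

Compound 3 gives > 10000 nM, a limit of the assay and not a number, so no step can be read between compound 2 and compound 3: the limit of > 10000 nM in this assay, at which 3 of the 3 values shown sit.

The compounds shown leave open how strong the inhibition by any of them is, and whether methoxymethyl on the aromatic ring changes it at all.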